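The compounds below may be only part of what the source reports. "The series", "measured", "known", "first", "only" and "open" are said of these compounds alone.

Compound 3 `CN(C)c1ccc(C2CC(c3ccc(-n4cncn4)cc3)=NN2C(=O)c2ccc(F)cc2)cc1` gives 12.5% in a functional assay on MDA-MB-231 cells (Homo sapiens) for inhibition, read by sulforhodamine B assay, tested at 10 uM (on this read-out higher numbers stand for more inhibition at the one concentration tested (going by the name of the read-out) and lower numbers for less inhibition), the highest of the three numbers, though its gaps to the other two lie within the scatter. Compound 2 `CN1CCN(c2ccc(C3=NN(S(=O)(=O)c4ccc(OC(F)(F)F)cc4)C(c4ccc(N(C)C)cc4)C3)cc2)CC1` gives 10.6% and compound 1 `CN1CCN(c2ccc(C3=NN(C(=O)c4ccc(F)cc4)C(c4ccc(N(C)C)cc4)C3)cc2)CC1` gives 3.5%; these two carry different groups on the ring nitrogen of the shared core, and both show weak inhibition. For the measured compounds named here, the one single-place step, a number 9 percentage points higher from compound 1 to compound 3 (within the scatter), is within the scatter. Compound 4 `CN(C)c1ccc(C2CC(c3ccc(-n4cncn4)cc3)=NN2S(=O)(=O)c2ccc(C#N)cc2)cc1` carries (4-cyanophenyl)sulfonyl in place of (4-fluorophenyl)carbonyl on an amine nitrogen in a ring. Going by the values given here, no measured step changes this group, so the expectation rests on the three low numbers alone; compound 4 is expected to show weak inhibition too, an estimated step of a number 0.5 percentage points lower from compound 3 to compound 4 (within the scatter). Compound 4 is therefore expected to give 12%, between 0% and 28%.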

Compound 4, a percentage reported as inhibition, at one concentration (the size of the read-out at that concentration, not a potency): 32.8%
Beside the measured number, compound 4's estimate is 20.8 percentage points below it; the whole stated range lies below it.
By their numbers in this assay, from the lowest: compounds 1, 2 and 3 (each within the scatter of the next); then compound 4.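

In this assay the group on the amine nitrogen in a ring gives the first step shown that clears the scatter: a number 20.3 percentage points higher from compound 3 to compound 4 (beyond the scatter) when (4-cyanophenyl)sulfonyl takes the place of (4-fluorophenyl)carbonyl. For the compounds shown here, the number at this position can therefore move, whereas the one earlier step, on an aromatic carbon, stayed within the scatter. Nothing at hand explains this step.

The swap changes both the carbonyl link and the ring's substituent, leaving open which one matters. (4-Fluorophenyl)sulfonyl or (4-cyanophenyl)carbonyl at this position would separate the two.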